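Amide to sulfonamide on a shared two-carbon linker

A few compounds are considered here, and "the series" means these few. Any claim that something is new, unique, unknown or untested is made for them only; others in the source may bear on it.

Measured compounds:
compound 1, `O=C(NCCNc1nccc(-c2c(-c3cccc(F)c3)nc3sccn23)n1)c1ccc(C(F)(F)F)cc1`, 9260 nM
compound 2, `O=C(NCCNc1nccc(-c2c(-c3cccc(F)c3)nc3sccn23)n1)c1ccc(Cl)cc1`, 8160 nM

In a functional assay on SK-MEL-28 cells (Homo sapiens) for cytotoxicity, read by MTT assay (a lower number here means a stronger inhibitor, a higher number a weaker inhibitor), compound 1 gives 9260 nM and compound 2 gives 8160 nM. Among the measured compounds shown here, the single measured step, a 1.1-fold lower number from compound 1 to compound 2 (0.05 log units; within the scatter), changes only the substituent on the outer aromatic ring and stays within the scatter, so compound 2 stands with the lowest of the two numbers, but not apart from compound 1 in this assay.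

Compound 3, `O=S(=O)(NCCNc1nccc(-c2c(-c3cccc(F)c3)nc3sccn23)n1)c1cccc(F)c1`, differs from compound 2 by (3-fluorophenyl)sulfonyl in place of (4-chlorophenyl)carbonyl on an amine nitrogen. For the measured compounds named here, this change touches the amide itself, not merely its aromatic substituent, and no measured step covers such a change; the one step that exists, a 1.1-fold lower number from compound 1 to compound 2 (0.05 log units; within the scatter), is small and bears only indirectly, through showing that the outer ring tolerates a swap of its substituent without a move beyond the scatter. On that thin basis compound 3 is expected to stay near compound 2 in this assay, with the estimated step of a 1.2-fold higher number from compound 2 to compound 3 (0.09 log units; within the scatter) carrying a wide range in either direction. The estimate for compound 3 is 10000 nM, between 3000 nM and 35000 nM.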

Compound 3, half-maximal inhibitory concentration: 18300 nM
Compound 3: the middle estimate sits 1.8-fold (0.26 log units) below what was measured; the measured number falls inside the stated range.
By their numbers in this assay, from the lowest: compounds 2, 1 and 3 (each within the scatter of the next, the first and the last beyond it).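

At the amine nitrogen, the change reaches the linking group itself rather than only a substituent on the outer aromatic ring, and in this assay the step of a 2.2-fold higher number from compound 2 to compound 3 (0.35 log units; beyond the scatter) is a modest one beyond the scatter, which the step between the two amides did not reach. Measured against the other amide, however, the step of a 2.0-fold higher number from compound 1 to compound 3 (0.30 log units; within the scatter) stays within the scatter, so compound 3 stands clearly apart from only one of the two amides and the replacement gives no sharp break at this position. Nothing shown here offers an explanation for the difference.

Because the sulfonyl replaces the carbonyl while the ring substituent also changes from 4-chloro to 3-fluoro, these three compounds do not separate the contribution of the linking group from that of the ring substituent. Open too, on these data alone, is how a (4-chlorophenyl)sulfonyl group, which would isolate the linking group, or a urea or a longer chain between the two nitrogens would fare in this assay on this core.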